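Swapping the aryl group on the ring amine of compound 2

This account rests on a few compounds, and the source may have more. Where it says the series, first, only, none or still open, it means among the compounds named here.

Measured so far:
- compound 1 `Nc1scc(CN2CCC(c3ccc(Cl)cc3)CC2)c1C(=O)c1ccc(Cl)cc1`: 0%
- compound 2 `Nc1scc(CN2CCN(c3ccc(C(F)(F)F)cc3)CC2)c1C(=O)c1cccc(C(F)(F)F)c1`: -12%

In a functional assay on CHO cells with adenosine receptor A1 (Homo sapiens) as the target, read by cAMP accumulation and immunoassay, with a stated time of 6 min, tested at 0.01 uM (a higher number here means a weaker effect of the compound at the concentration tested, a lower number a stronger effect), compound 1 gives 0% and compound 2 gives -12%. Compound 2 has the lowest of the two numbers; its nearest neighbour is compound 1, and the gap between them lies beyond the usual scatter. Both numbers are small, so neither compound shows much effect at the concentration tested.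

Compound 3 `Nc1scc(CN2CCN(c3c(F)cccc3F)CC2)c1C(=O)c1cccc(C(F)(F)F)c1` has not been measured in this assay. It differs from compound 2 in one place: 2,6-difluorophenyl in place of 4-(trifluoromethyl)phenyl on an amine nitrogen in a ring

Within the data shown here, no step between measured compounds shows what this kind of exchange does. With compound 2 at -12% and compound 1 at 0%, the step of a number 7 percentage points higher from compound 2 to compound 3 (within the scatter) is expected to be small, no larger than the scatter, in no firm direction. Compound 3 is therefore estimated at -5%, within a range from -20% to 10%.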

Compound 3, a percentage reported as activity, at one concentration (the size of the read-out at that concentration, not a potency): 2.1%
Estimate against measurement, compound 3: 7.1 percentage points below, within the range that was stated.
By their numbers in this assay, from the lowest: compound 2; then compounds 1 and 3 (each within the scatter of the next).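

In this assay, among these compounds, placing 2,6-difluorophenyl in place of 4-(trifluoromethyl)phenyl on an amine nitrogen in a ring gives a number 14.1 percentage points higher from compound 2 to compound 3 (beyond the scatter), the first step at this position that can be read. A higher number here means a weaker effect, so the read-out at this one concentration does respond to the aryl group on this nitrogen, though the step is modest and both numbers stay small. No measurement is available that explains this step.

This single exchange removes the trifluoromethyl group and brings in two fluorines at once, so it cannot show which part of the change matters; a plain phenyl group on the same nitrogen would help to separate the two. Results at a single concentration also leave open how potent any of these compounds is.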